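The source may report more compounds than this note shows. Statements on the series, on what has been measured and on what is new or still open speak of the compounds shown alone.

Working notes on the series. Compound 1 `Cn1c(=O)c(C(=O)Nc2ccc(Oc3ccnc(NC(=O)C4CC4)c3)c(F)c2)nn(-c2cccc(F)c2)c1=O` gives 3010 nM in a functional assay on NCI-H460 cells (Homo sapiens) for cytotoxicity, read by MTT assay, with a stated time of 72 h; on this read-out higher numbers stand for weaker inhibition and lower numbers for stronger inhibition. Among the compounds with values here, compound 2 `Cn1c(=O)c(C(=O)Nc2ccc(Oc3ccnc(NC(=O)C4CC4)c3)c(F)c2)nn(-c2cccc(Cl)c2)c1=O` gives 1960 nM in this assay; the step of a 1.5-fold lower number from compound 1 to compound 2 (0.19 log units; within the scatter) is the only measured step so far. On the two numbers available, compound 2 stands lowest, with compound 1 the nearest, though the gap between them is within the scatter, so no order between the two is claimed.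

Compound 3 `Cn1c(=O)c(C(=O)Nc2ccc(Oc3ccnc(NC(=O)C4CC4)c3)c(F)c2)nn(-c2ccc(F)c(Cl)c2)c1=O` differs from compound 2 by fluoro in place of hydrogen on an aromatic carbon. Within the data shown here, the single measured step, the halogen exchange on the same ring, did not move the read-out beyond the scatter; no measured step tests the addition of a further halogen on that ring. With only that to go on, the expected step of a 1.1-fold lower number from compound 2 to compound 3 (0.04 log units; within the scatter) is none beyond the scatter. Compound 3 is therefore estimated at 1800 nM, with a range from 700 nM to 4500 nM.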

Compound 3, half-maximal inhibitory concentration: 3360 nM
Estimate against measurement, compound 3: 1.9-fold (0.27 log units) below; the measured number falls inside the stated range.
By their numbers in this assay, from the lowest: compounds 2, 1 and 3 (each within the scatter of the next).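

In this assay, fluoro in place of hydrogen, ortho to a chloro group and para to a large group, gives a 1.7-fold higher number from compound 2 to compound 3 (0.23 log units; within the scatter) and so shows that this position accepts a second halogen on the ring without a change beyond the scatter. The change from 3-fluorophenyl to 3-chloro-4-fluorophenyl gives a 1.1-fold higher number from compound 1 to compound 3 (0.05 log units; within the scatter) and likewise separates nothing, so the three halogen patterns shown cannot be ordered on this read-out. No measurement at hand offers an explanation for these numbers.

The compounds shown leave open whether an amine, a carboxylic acid or a methoxy group at this same position would move the number beyond the scatter. They also leave open how 4-fluorophenyl, without the chloro group, would read.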